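Removing the side chain of compound 2

The source may hold more compounds than are shown below. What is called first, only, known or untested is meant among the compounds shown, and "the series" means these compounds.

In an assay on nucleic acid for binding affinity to Nucleic Acid, read by fluorescence (a higher number here means that more compound is needed for the effect, a lower number that less compound is needed), compound 2 `NCCCC[C@H](N)C(=O)N[C@@H]1C[C@H](N)[C@@]2(CC[C@H](O)[C@H](O)CO2)[C@H](O)[C@H]1O` gives 12000 nM and lies within the usual scatter of compound 1 `N[C@@H]1C[C@H](N)[C@@]2(C[C@H](O)[C@H](O)CO2)[C@H](O)[C@H]1O` at 6500 nM in the same test. Compound 3 `C=CCC(C)(C)CN[C@@H]1C[C@H](N)[C@@]2(CCC=CCO2)[C@H](O)[C@H]1O` gives 63000 nM and stands clearly above compound 2, so more of it is needed for the effect. Compound 4 `N[C@@H]1C[C@H](N)[C@@]2(CC[C@H](O)[C@H](O)CO2)[C@H](O)[C@H]1O` comes from compound 2 by one change, hydrogen in place of (1,5-diaminopentyl)carbonyl on an amine nitrogen and no other. Going by the values given here, no measured pair shows this change alone. Compound 1 also carries no such group, and its 6500 nM gives no hint of a large shift, although its core is not identical. A small upward step within the scatter is expected in this assay and the estimated step is a 1.3-fold higher number from compound 2 to compound 4 (0.10 log units; within the scatter) for now. For compound 4 the estimate is 15000 nM with an expected range of 5000 nM to 50000 nM in this test.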

Compound 4, half-maximal effective concentration: 74000 nM
For compound 4 the middle estimate is 4.9-fold (0.69 log units) below the measured one; measured number outside the range, above it.
By their numbers in this assay, from the lowest: compounds 1 and 2 (each within the scatter of the next); then compounds 3 and 4 (each within the scatter of the next).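

In this assay replacing the (1,5-diaminopentyl)carbonyl on the amine nitrogen with hydrogen gives a 6.2-fold higher number from compound 2 to compound 4 (0.79 log units; beyond the scatter) and so shows that more compound is needed without this group. Going by these compounds alone, this is the first pair here that differs in one place only, which makes it the first direct reading of this position. Nothing measured here explains the step.

The compounds shown leave open whether the whole group is needed, or whether a plain acetyl, which keeps the carbonyl but has no chain or amines, would serve as well.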